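The source may hold more compounds than are shown below. What is called first, only, known or untested is meant among the compounds shown, and "the series" means these compounds.

Compound 1 `COc1cc(NC(=O)Nc2cc(Nc3ccc(OC)c(C)c3)ncn2)cc(OC)c1` gives 13.5% in a functional assay on NCI-H520 cells (Homo sapiens) for inhibition, read by MTT assay, with a stated time of 48 h, tested at 10 uM; a higher number here means more inhibition at the concentration tested (going by the name of the read-out), a lower number less inhibition. Compound 2 `COc1cc(Br)ccc1Nc1cc(NC(=O)Nc2c(Cl)cccc2Cl)ncn1` gives 29.1%. Compound 3 `COc1cc(Nc2cc(NC(=O)Nc3c(Cl)cccc3Cl)ncn2)cc(OC)c1` gives 55.5%.

Among these three, compound 1 stands lowest; compound 2 lies higher by a margin beyond the scatter, and compound 3 higher still. Among the measured compounds shown here, no two of the measured compounds differ in a single place, so no measured step bears directly on the change considered here.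

Compound 4 `COc1cc(NC(=O)Nc2cc(Nc3cc(C)cc(F)c3)ncn2)cc(OC)c1` differs from compound 1 at one site: 3-fluoro-5-methylphenyl in place of 4-methoxy-3-methylphenyl on a nitrogen on an aromatic ring. For the measured compounds named here, the measured compounds offer no step of this kind to guide the expectation, so the change is expected to leave the number about where compound 1 sits, with no shift beyond the scatter in either direction. Compound 4 is therefore estimated at 15%, within 0% to 35%, a step of a number 1.5 percentage points higher from compound 1 to compound 4 (within the scatter).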

Compound 4, a percentage reported as inhibition, at one concentration (the size of the read-out at that concentration, not a potency): 24.5%
Estimate against measurement, compound 4: 9.5 percentage points below, within the range that was stated.
By their numbers in this assay, from the lowest: compound 1; then compounds 4 and 2 (each within the scatter of the next); then compound 3.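

Placing 3-fluoro-5-methylphenyl on this nitrogen in place of 4-methoxy-3-methylphenyl gives, in this assay, a number 11 percentage points higher from compound 1 to compound 4 (beyond the scatter) and this modest step is the first measured at this position. It shows that the number responds to the aryl group here while the rest of compound 1 stays fixed. No measurement shown accounts for the step.

Going by these compounds, it remains open how a plain phenyl, or a phenyl carrying a carboxylic acid or a dimethylamino group, would read on this nitrogen. Whether the same change carries over to a different group elsewhere on the shared core is also unsettled.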